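Oxime ether series at the dopamine D4 receptor: aryl swap

The source may report more compounds than this note shows. Statements on the series, on what has been measured and on what is new or still open speak of the compounds shown alone.

The account starts from compound 1 `Cc1ccccc1/C(CCN1CCN(c2ccccn2)CC1)=N/O`, which in a functional assay on HEK293 cells with D(4) dopamine receptor (Homo sapiens) as the target, read by FLIPR (on this read-out lower numbers stand for an effect already at smaller amounts and higher numbers for an effect only at larger amounts of compound), gives 4.2 nM. This is the lowest of the three numbers in hand. Its geometric isomer, compound 2 `Cc1ccccc1/C(CCN1CCN(c2ccccn2)CC1)=N\O`, gives 20.3 nM in this assay; the step of a 4.8-fold higher number from compound 1 to compound 2 (0.68 log units; beyond the scatter) is tied to the fact that compounds 1 and 2 differ only in the configuration as drawn. Among the measured compounds shown here, compound 3 `O/N=C(\CCN1CCN(c2ccccn2)CC1)c1cccc(Cl)c1` carries a 3-chlorophenyl in place of the 2-methylphenyl and gives 11.9 nM, so that a 2.8-fold higher number from compound 1 to compound 3 (0.45 log units; beyond the scatter) is the only step so far that changes the aromatic ring.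

Compound 4 `O/N=C(\CCN1CCN(c2ccccn2)CC1)c1ccc(F)cc1` is the next ring variant: 4-fluorophenyl in place of 2-methylphenyl on a carbon with a double bond to nitrogen. For the measured compounds named here, of the measured steps, only the one from compound 1 to compound 3 bears on this change, since it also exchanges the 2-methylphenyl for a halogen-bearing phenyl, and that step raised the number modestly. The geometry of the double bond is kept as in compound 1, so the step to compound 2 gives no guidance here. A modest rise in this assay is therefore the expectation, with the outcome for compound 4 estimated as a 2.4-fold higher number from compound 1 to compound 4 (0.38 log units; beyond the scatter). Compound 4 is accordingly expected to give about 10 nM, within a range from 3 nM to 35 nM, before the measurement is known.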

Compound 4, half-maximal effective concentration: 31 nM
Compound 4: the middle estimate sits 3.1-fold (0.49 log units) below what was measured; the range from low to high includes it.
By their numbers in this assay, from the lowest: compound 1; then compounds 3, 2 and 4 (each within the scatter of the next, the first and the last beyond it).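

In this assay, a second ring exchange at this place, on a carbon with a double bond to nitrogen, again raises the number: a 7.4-fold higher number from compound 1 to compound 4 (0.87 log units; beyond the scatter). The two halogen-bearing rings shown also differ from each other, a 2.6-fold higher number from compound 3 to compound 4 (0.42 log units; beyond the scatter), so the outcome depends on which ring is present, and the 2-methylphenyl and 4-fluorophenyl groups show that a change of this size can occur even when the heavy-atom count stays the same. Nothing in the available evidence bears on why the 4-fluorophenyl ring gives this result.

The compounds shown leave open how much of the step comes from the change of substituent and how much from its place on the ring, a question that 2-fluorophenyl and 4-methylphenyl groups at the same carbon would address. Also open, going by these compounds, are the effect of the opposite double-bond geometry when the ring is 4-fluorophenyl, and how an unsubstituted phenyl or a 4-methoxyphenyl group would compare.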